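This account rests on a few compounds, and the source may have more. Where it says the series, first, only, none or still open, it means among the compounds named here.

Compound 1 `COc1cc(-c2c(C)nn(-c3nc(-c4ccc(Cl)c(Cl)c4)c(SC(C)C)s3)c2C(=O)O)cc(C(F)(F)F)c1` gives 1380 nM in a functional assay on BJAB cells (Homo sapiens) for antiproliferative activity, with a stated time of 4 days; on this read-out lower numbers stand for an effect already at smaller amounts and higher numbers for an effect only at larger amounts of compound.
Compound 2 `Cc1nn(-c2nc(-c3ccc(Cl)c(Cl)c3)c(SC(C)C)s2)c(C(=O)O)c1-c1cncc(C#N)c1` gives 20000 nM in this assay.
Compound 3 `Cc1cc(C#N)cc(-c2c(C)nn(-c3nc(-c4ccc(Cl)c(Cl)c4)c(SC(C)C)s3)c2C(=O)O)c1` gives 4800 nM in this assay.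

Compound 3 stands second highest of the three numbers. The change a 3.5-fold higher number from compound 1 to compound 3 (0.54 log units; beyond the scatter) places it beyond the scatter from compound 1, and the change a 4.2-fold lower number from compound 2 to compound 3 (0.62 log units; beyond the scatter) places it beyond the scatter from compound 2, so it sits between the two.

Compound 4 `Cc1nn(-c2nc(-c3ccc(Cl)c(Cl)c3)c(SC(C)C)s2)c(C(=O)O)c1-c1cnccn1` differs from compound 3 in one place: pyrazin-2-yl in place of 3-cyano-5-methylphenyl on an aromatic carbon. For the measured compounds named here, two measured steps bear on this. The change a 14-fold higher number from compound 1 to compound 2 (1.16 log units; beyond the scatter) shows that a six-membered ring with one nitrogen in place of a carbon-only ring went with a large rise in the number; the change a 4.2-fold lower number from compound 2 to compound 3 (0.62 log units; beyond the scatter) shows the reverse direction. The ring entering here carries two nitrogens and no other groups, so a clearly higher number is expected in this assay, with the step of a 6.3-fold higher number from compound 3 to compound 4 (0.80 log units; beyond the scatter) estimated. Compound 4 is expected to give about 30000 nM, within 8000 nM to 100000 nM, and the assay may report only a limit.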

Compound 4, half-maximal effective concentration: 14000 nM
The estimate for compound 4 lay 2.1-fold (0.33 log units) above the measured number; measured number inside the range.
By their numbers in this assay, from the lowest: compound 1; then compound 3; then compounds 4 and 2 (each within the scatter of the next).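

Placing pyrazin-2-yl on this aromatic carbon of the shared core gives a 2.9-fold higher number from compound 3 to compound 4 (0.46 log units; beyond the scatter) in this assay and a 10-fold higher number from compound 1 to compound 4 (1.01 log units; beyond the scatter), so this smaller ring also goes with a higher number than either carbon-only ring. Against the other nitrogen-containing ring, the result is a 1.4-fold lower number from compound 2 to compound 4 (0.15 log units; within the scatter), so pyrazin-2-yl and 5-cyanopyridin-3-yl cannot be told apart here, although only the latter carries a nitrile. Across these four compounds, with none going against it, both rings containing nitrogen give higher numbers than both carbon-only rings.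

Nothing measured here explains this pattern or shows whether it follows the ring nitrogens or the groups on each ring. A phenyl ring carrying an amine, or a pyridine ring carrying a methoxy group, would help separate these two features.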